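Substituent variation on the sulfur-bound chain carbon

This account rests on a few compounds, and the source may have more. Where it says the series, first, only, none or still open, it means among the compounds named here.

Measured compounds:
compound 1 `Cc1cc(Nc2cc(-c3ccccc3)[nH]n2)n2nc(SCc3nc4ccccc4[nH]3)nc2n1` — 1790 nM
compound 2 `Cc1cc(Nc2cc(-c3ccccc3)[nH]n2)n2nc(SCc3ccccc3Br)nc2n1` — 3650 nM
compound 3 `Cc1cc(Nc2cc(-c3ccccc3)[nH]n2)n2nc(SCc3cccc4ccccc34)nc2n1` — 3120 nM

All three compounds share one core and differ only in the group on a saturated chain carbon bound to a sulfur. In a functional assay on MGC-803 cells (Homo sapiens) for inhibition, read by MTT assay, with a stated time of 72 h (on this read-out lower numbers stand for stronger inhibition and higher numbers for weaker inhibition), compound 1 gives 1790 nM, compound 2 gives 3650 nM and compound 3 gives 3120 nM. Compound 3 stands second highest of the three numbers; its nearest neighbour is compound 2 a 1.2-fold lower number from compound 2 to compound 3 (0.07 log units; within the scatter) and its furthest is compound 1 a 1.7-fold higher number from compound 1 to compound 3 (0.24 log units; within the scatter), both within the scatter. Going by the values given here, the only step beyond the scatter is a 2.0-fold higher number from compound 1 to compound 2 (0.31 log units; beyond the scatter), a modest rise.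

Compound 4 `Cc1cc(Nc2cc(-c3ccccc3)[nH]n2)n2nc(SCC3CCCCC3)nc2n1` is not yet measured. Relative to compound 3 the change is cyclohexyl in place of naphthalen-1-yl on a saturated chain carbon bound to a sulfur. Among the compounds with values here, no measured step exchanges an aromatic group for a non-aromatic one at this position, so the measured steps bear on it only indirectly: exchanging 1H-benzimidazol-2-yl, 2-bromophenyl and naphthalen-1-yl moves the number little. In this assay a small rise or no step beyond the scatter is therefore expected for compound 4, with a wide range. Compound 4 is expected to give 4500 nM (range 1500 nM to 14000 nM). The expected step is a 1.4-fold higher number from compound 3 to compound 4 (0.16 log units; within the scatter).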

Compound 4, half-maximal inhibitory concentration: 12600 nM
Beside the measured number, compound 4's estimate is 2.8-fold (0.45 log units) below it; measured number inside the range.
By their numbers in this assay, from the lowest: compounds 1, 3 and 2 (each within the scatter of the next, the first and the last beyond it); then compound 4.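

In this assay, cyclohexyl on the saturated chain carbon bound to a sulfur separates from all three aromatic groups, with each step lying beyond the scatter (a 4.0-fold higher number from compound 3 to compound 4 (0.61 log units; beyond the scatter); a 3.5-fold higher number from compound 2 to compound 4 (0.54 log units; beyond the scatter); a 7.0-fold higher number from compound 1 to compound 4 (0.85 log units; beyond the scatter)), whereas exchanges among those aromatic groups moved the number far less. Going by these compounds alone, this position therefore tolerates different aromatic groups better than it tolerates the one group here with a non-aromatic ring, although that reading rests on compound 4 alone. The change from naphthalen-1-yl to cyclohexyl alters the ring count, the heavy-atom count and aromatic character in a single step, so these compounds cannot assign the rise to any one of them, and no available evidence gives a cause for it.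

An unsubstituted phenyl, a piperidin-4-yl ring or a straight butyl chain at this carbon could help separate the loss of an aromatic ring from the loss of ring atoms. Also open, on these data alone, is whether the order of these four compounds holds outside this assay in other cell lines.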